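Replacing the large group of compound 3 with hydrogen

This account rests on a few compounds, and the source may have more. Where it says the series, first, only, none or still open, it means among the compounds named here.

In a physicochemical assay for lipophilicity, at pH 7.4 (a lower number here means a more polar compound, a higher number a more lipophilic compound), compound 3 (`CNC(=O)c1cc(C(=O)NCCC[C@H]2OC[C@H](N)CO2)cc2c1OC[C@H]2c1ccccc1`) gives 2.6, the lowest of three numbers, against compound 1 (`CCC(=O)N1C[C@@H]2[C@H](C1)[C@H]2NC(=O)c1cc(C(=O)NC)c2c(c1)[C@H](c1ccccc1)CO2`) at 3.4 and compound 2 (`CNC(=O)c1cc(C(=O)Nc2cnn(C)c2)cc2c1OC[C@H]2c1ccccc1`) at 3.5. The next structure, compound 4 (`CNC(=O)c1cc(C(=O)NC)c2c(c1)[C@H](c1ccccc1)CO2`), differs from compound 3 by one change: a hydrogen atom in place of a group of 9 heavy atoms (6 carbon, 1 nitrogen, 2 oxygen; one six-membered non-aromatic ring with 2 hetero atoms), on a saturated chain carbon bound to an amide-type nitrogen.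

Among the measured compounds shown here, no measured step makes this exact change, but three steps swap groups on an amide-type nitrogen and offer a guide. Two of them end at compound 3 and are modest but beyond the scatter: a number 0.80 log units lower from compound 1 to compound 3 (beyond the scatter) and a number 0.90 log units lower from compound 2 to compound 3 (beyond the scatter). The third, a number 0.10 log units higher from compound 1 to compound 2 (within the scatter), lies within the scatter, so two quite different groups gave numbers that cannot be separated.

Compound 3 thus stands apart from the other two, and leaving its group behind is expected to give a modest rise of similar size in this assay. The expected step is a number 0.70 log units higher from compound 3 to compound 4 (beyond the scatter). For compound 4 the estimate is 3.3, with an expected range from 2.8 to 3.8.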

Compound 4, distribution coefficient: 3.2
Compound 4: middle estimate off by 0.10 log units, on the high side; measured number inside the range.
By their numbers in this assay, from the lowest: compound 3; then compounds 4, 1 and 2 (each within the scatter of the next).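

In this assay the step of a number 0.60 log units higher from compound 3 to compound 4 (beyond the scatter) ties the low number of compound 3 to its group of 9 heavy atoms, with its six-membered non-aromatic ring, and not to the shared core. The methyl on the amide-type nitrogen of compound 4 cannot be separated from the groups of the other two compounds, as a number 0.30 log units lower from compound 2 to compound 4 (within the scatter) and a number 0.20 log units lower from compound 1 to compound 4 (within the scatter) show, so among these four compounds only the group of compound 3 stands apart. Nothing at hand says which part of that group goes with the lower number.

On these data alone, it remains open whether the same ring without its nitrogen would give the same number. As far as these compounds go, it is also open whether a carboxylic acid or a longer plain carbon chain in this place would fall with compound 3 or with compound 4.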